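Moving the selenocyanate: from compound 3 to compound 4

A few compounds are considered here, and "the series" means these few. Any claim that something is new, unique, unknown or untested is made for them only; others in the source may bear on it.

compound 1 `COc1ccc(N(C)c2nc(C)nc3ccccc23)cc1C(=O)OCC[Se]C#N`: 353 nM
compound 2 `Cc1nc(N(C)c2ccc([Se]C#N)c(C)c2)c2ccccc2n1`: 8 nM
compound 3 `COc1ccc(N(C)c2nc(C)nc3ccccc23)cc1C(=O)NCC[Se]C#N`: 187 nM
compound 4 `COc1ccc(N(C)c2nc(C)nc3ccccc23)cc1[Se]C#N`: not yet measured

In a functional assay on A549 cells (Homo sapiens) for inhibition, read by MTT assay, with a stated time of 48 h (on this read-out higher numbers stand for weaker inhibition and lower numbers for stronger inhibition), compound 3 gives 187 nM, level within the scatter with compound 1 and well above compound 2 at 8 nM. The next change is a group of 3 heavy atoms (1 carbon, 1 nitrogen, 1 selenium; no ring) in place of a group of 8 heavy atoms (4 carbon, 2 nitrogen, 1 oxygen, 1 selenium; no ring), on an aromatic carbon. Among the compounds with values here, the only measured step, a 1.9-fold lower number from compound 1 to compound 3 (0.28 log units; within the scatter), alters the chain but does not remove it, so it bears only weakly. Closer is compound 2 at 8 nM, which also carries this small group on an aromatic carbon. However, compound 2 differs from compound 4 elsewhere too, so the size stays uncertain. A step to a lower number, beyond the scatter, is expected in this assay. The expected step is a 6.2-fold lower number from compound 3 to compound 4 (0.79 log units; beyond the scatter). Compound 4 is estimated at 30 nM, within a range of 8 nM to 120 nM.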

Compound 4, half-maximal inhibitory concentration: 49 nM
The estimate for compound 4 lay 1.6-fold (0.21 log units) below the measured number, within the range that was stated.
By their numbers in this assay, from the lowest: compound 2; then compound 4; then compounds 3 and 1 (each within the scatter of the next).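

In this assay the selenocyanate set directly on the aromatic carbon, ortho to a methoxy group, gives a 3.8-fold lower number from compound 3 to compound 4 (0.58 log units; beyond the scatter) in place of the amide chain and a 7.2-fold lower number from compound 1 to compound 4 (0.86 log units; beyond the scatter) in place of the ester chain. Removing the whole chain thus moves the number beyond the scatter at this position, which exchanging the ester link for the amide link did not do. No measurement shown gives a reason for this difference.

Open, going by these compounds, is whether a shorter or longer chain carrying the selenocyanate would fall between these numbers. Also open, on these data alone, is how a simple nitrile, an amine or a carboxylic acid on this aromatic carbon would compare.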